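The source may report more compounds than this note shows. Statements on the series, on what has been measured and on what is new or still open speak of the compounds shown alone.

Working notes on the series.

Going by the values given here, compound 1 `Brc1ccc2[nH]c(-c3cncn3Cc3ccccc3)cc2c1` gives 11000 nM in an assay on HEK293 cells for inhibition of Indoleamine 2,3-dioxygenase 1 (Homo sapiens), with a stated time of 30 min (a lower number here means that less compound is needed, a higher number that more compound is needed for the effect), and stands as the highest of the two numbers so far; its nearest neighbour is compound 2 `Cc1ccc(Cn2cncc2-c2cc3cc(Br)ccc3[nH]2)cc1`, which gives 4290 nM in this assay. Among the compounds with values here, the only step between measured compounds, a 2.6-fold lower number from compound 1 to compound 2 (0.41 log units; beyond the scatter), comes from methyl in place of hydrogen on an aromatic carbon of the benzyl ring.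

Compound 3 `FC(F)(F)c1ccc(Cn2cncc2-c2cc3cc(Br)ccc3[nH]2)cc1` is the next member awaiting a number. It differs from compound 1 by trifluoromethyl in place of hydrogen on an aromatic carbon, at the same position as the methyl of compound 2. Within the data shown here, the one step that bears on it is a 2.6-fold lower number from compound 1 to compound 2 (0.41 log units; beyond the scatter), a modest lowering beyond the scatter. Among the measured compounds shown here, on that basis a lowering of comparable size is expected for compound 3 in this assay, though with only one step to go on the range is kept wide. Compound 3 is therefore estimated at 5000 nM, between 2000 nM and 14000 nM, which means an expected step of a 2.2-fold lower number from compound 1 to compound 3 (0.34 log units; beyond the scatter).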

Compound 3, half-maximal effective concentration: 4590 nM
The estimate for compound 3 lay 1.1-fold (0.04 log units) above the measured number, and the stated range covers the measured number.
By their numbers in this assay, from the lowest: compounds 2 and 3 (each within the scatter of the next); then compound 1.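

At this position, on an aromatic carbon para to a large group, the lower number is no longer tied to methyl alone: in this assay, trifluoromethyl in place of hydrogen also gives a step beyond the scatter (a 2.4-fold lower number from compound 1 to compound 3 (0.38 log units; beyond the scatter)). Trifluoromethyl in place of methyl gives a step within the scatter (a 1.1-fold higher number from compound 2 to compound 3 (0.03 log units; within the scatter)), so this assay does not separate these two groups at this position. No supporting data are available to explain the shared step from hydrogen or the lack of separation between the two groups.

On these data alone, whether the lower number extends to an amine, a carboxylic acid or a longer chain at this position remains open. Also open, as far as these compounds go, is whether methyl and trifluoromethyl would stay within the scatter of each other with chlorine in place of the bromine on the shared core.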